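Working notes: methoxy step from compound 2 to compound 3

The compounds below may be only part of what the source reports. "The series", "measured", "known", "first", "only" and "open" are said of these compounds alone.

Compound 1 `O=C1CS/C(=N\c2csc(-c3ccccc3)c2)N1` is the plainest member of the series. In a functional assay on HCT-116 cells (Homo sapiens) for cytotoxicity, read by MTT assay, with a stated time of 72 h (on this read-out higher numbers stand for weaker inhibition and lower numbers for stronger inhibition), compound 1 gives > 50000 nM, which is a limit of the assay and not a number. Compound 2 `COc1cccc(N2C(=O)CS/C2=N\c2csc(-c3ccccc3)c2)c1` is the next member. In this assay compound 2 gives "not determined" (no result reported), so no number places it. Where compound 2 stands can therefore be read only against what else is shown, and that is the limit of > 50000 nM in this assay, at which 1 of the 2 values shown sits; compound 2 has no value of its own to set beside it.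

Compound 3 `COc1ccc(-c2cc(/N=C3\SCC(=O)N3c3cccc(OC)c3)cs2)cc1` is the unmeasured member. It differs from compound 2 by methoxy in place of hydrogen on an aromatic carbon. Among the compounds with values here, no step between two measured compounds exists, so the size of this step in this assay has no precedent here; a change of no more than the usual scatter, in either direction, is expected.

Compound 3 is expected to remain weak in this assay because compound 1 shows > 50000 nM, a limit. Compound 3 is estimated at 40000 nM in this assay, with a range from 10000 nM to 100000 nM.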

Compound 3, half-maximal inhibitory concentration: 2700 nM
Compound 3: middle estimate off by 15-fold (1.17 log units), on the high side; the whole stated range lies above it.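

Within the data shown here, compound 2 has no number in this assay, so no step from compound 2 to compound 3, which gives 2700 nM, can be read. The compounds shown leave open what the change from phenyl to 4-methoxyphenyl is worth in this assay, as no pair differing only in that place carries two numbers.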